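Cyano for methoxy in two non-toxic cores

The source may hold more compounds than are shown below. What is called first, only, known or untested is meant among the compounds shown, and "the series" means these compounds.

Compound 3 `COc1cccc(-c2cnc(NC(=O)c3ncc[nH]3)n2C)c1` and compound 2 `COc1ccc(-c2cnc(NC(=O)c3ccc(F)cc3)n2C)cc1` share the amide-linked arrangement, but the difference between the two cores is not broken down here. The measured pair is compound 2 and compound 1 `Cn1c(-c2ccc(C#N)cc2)cnc1NC(=O)c1ccc(F)cc1`, where cyano in place of methoxy on an aromatic carbon is the change. In a toxicity assay on THP-1 cells (Homo sapiens) for inhibition (a higher number here means that more compound is tolerated, a lower number that less compound is tolerated), compound 2 gives a value that is a limit, >= 50000 nM. In this assay compound 1 also gives a limit, > 50000 nM. The step that the two limits leave unreadable from compound 2 to compound 1 therefore cannot be sized, since both values sit at limits the limit of > 50000 nM in this assay, at which 1 of the 3 values shown sits, and (the limit of >= 50000 nM in this assay, at which 1 of the 3 values shown sits).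

Compound 4 `Cn1c(-c2cccc(C#N)c2)cnc1NC(=O)c1ncc[nH]1` arises from compound 3 by cyano in place of methoxy on an aromatic carbon; this is the same kind of change as before, but the place differs, meta to a large group here against para to a large group in the measured pair. In this assay compound 3 gives a limit, > 100000 nM, as the limit of > 100000 nM in this assay, at which 1 of the 3 values shown sits, records.

For compound 4 the expectation is that the step of a number no higher from compound 3 to compound 4 (the limit leaves the size open) stays small, resting on compound 3 at > 100000 nM and on the unreadable measured step. Compound 4 is thus estimated at 100000 nM in this assay, most probably reported only as a limit.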

Compound 4, half-maximal cytotoxic concentration: > 50000 nM
Compound 4 was reported as a limit (the forecaster's own chance of this, stated with the estimate: 80%); the middle value lies beyond the limit too.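

Compound 3 and compound 4 both sit at limits in this assay, so no step can be read between them, and the same holds for compound 2 and compound 1. The compounds shown leave open whether cyano in place of methoxy changes the tolerated concentration at all in either core, and by how much.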